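This account rests on a few compounds, and the source may have more. Where it says the series, first, only, none or still open, it means among the compounds named here.

Measured so far in a toxicity assay on THP-1 cells (Homo sapiens) for inhibition (a higher number here means that more compound is tolerated, a lower number that less compound is tolerated), every entry a limit:
compound 1 `COc1ccc(-c2cnc(NC(=O)c3ccccc3O)n2C)cc1`: > 100000 nM
compound 2 `COc1ccc(-c2cnc(NC(=O)c3cccc(Cl)c3)n2C)cc1`: > 28000 nM
compound 3 `COc1ccc(-c2cnc(NC(=O)c3ccn[nH]3)n2C)cc1`: > 100000 nM

Compound 3 stands at the limit of > 100000 nM in this assay, at which 2 of the 3 values shown sit. Compound 2 stands at the limit of > 28000 nM in this assay, at which 1 of the 3 values shown sits. None of the three has a readable number, so no order can be drawn among them.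

Compound 4 `COc1ccc(-c2cnc(NC(=O)c3ccccn3)n2C)cc1` carries pyridin-2-yl in place of 1H-pyrazol-5-yl on a carbonyl carbon, (pyridin-2-yl in place of 1H-pyrazol-5-yl on a carbonyl carbon).

The three measured exchanges at this same place bear on the change: a step that the two limits leave unreadable from compound 1 to compound 2, a step that the two limits leave unreadable from compound 1 to compound 3 and a step that the two limits leave unreadable from compound 2 to compound 3. None of them gives a size. They show only that 2-hydroxyphenyl, 3-chlorophenyl and 1H-pyrazol-5-yl on this carbonyl carbon all ended in a limit, and none produced a readable value. This is thin evidence, but it gives no ground for expecting a step beyond the scatter in this assay, in either direction.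

The expected step is an at least 1.1-fold lower number from compound 3 to compound 4 (0.04 log units; that floor lies within the scatter), which is estimated to be no real change. A further limit is the most likely report. Compound 4 is estimated at 90000 nM, with an expected range from 30000 nM to 150000 nM.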

Compound 4, half-maximal cytotoxic concentration: > 100000 nM
Compound 4: no number, only a limit (the forecaster's own chance of this, stated with the estimate: 80%); at least 1.1-fold (0.04 log units) between middle value and limit.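

In this assay, among these compounds, compound 4 gives > 100000 nM, a limit and not a number, so no step from compound 1, compound 2 or compound 3 to compound 4 can be read. The compounds shown leave open at what concentration any of the four stops being tolerated, and whether the group on the carbonyl carbon changes that concentration.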